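A few compounds are considered here, and "the series" means these few. Any claim that something is new, unique, unknown or untested is made for them only; others in the source may bear on it.

Measured in a functional assay on HBC5 cells (Homo sapiens) for inhibition, read by colorimetric assay and sulforhodamine B assay, with a stated time of 48 h; a higher number here means a weaker inhibitor of growth, a lower number a stronger inhibitor of growth:
compound 1 `CCCCCCCCCCCC[C@@H](O)[C@H]1CC[C@H]([C@H](O)CCCCCCCCCCNC(=O)c2cccs2)O1` gives 3240 nM
compound 2 `CCCCCCCCCCCC[C@@H](O)[C@H]1CC[C@H]([C@H](O)CCCCCCCCCCNC(=O)c2ccco2)O1` gives 100000 nM

Of these two, compound 2 stands highest, at 100000 nM, which makes it the weaker inhibitor of growth. Compound 3 `CCCCCCCCCCCC[C@@H](O)[C@H]1CC[C@H]([C@H](O)CCCCCCCCCCNC(=O)c2ccoc2)O1` has not yet been measured in this assay. It differs from compound 2 as follows: furan-3-yl in place of furan-2-yl on a carbonyl carbon. In short, it carries furan-3-yl in place of furan-2-yl on a carbonyl carbon.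

Among the measured compounds shown here, only one measured step bears on this change: a 31-fold higher number from compound 1 to compound 2 (1.49 log units; beyond the scatter), with furan-2-yl in place of thiophen-2-yl on a carbonyl carbon. That large step shows that an exchange at this place can move the number far, though it involves a different ring. For the measured compounds named here, no measured step shows the effect of moving the furan attachment, so the direction remains uncertain. Since compound 2 holds the higher value, 100000 nM, a lower number is the more likely outcome.

The expected change is a 6.7-fold lower number from compound 2 to compound 3 (0.82 log units; beyond the scatter). For compound 3 the estimated value is 15000 nM, with an expected range of 3000 nM to 60000 nM.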

Compound 3, concentration for 50% growth inhibition: 100000 nM
Compound 3: the middle estimate sits 6.7-fold (0.82 log units) below what was measured; the measured number lies above the stated range.
By their numbers in this assay, from the lowest: compound 1; then compounds 2 and 3 (each within the scatter of the next).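

In this assay, moving the attachment of the furan on the carbonyl carbon gives no change at the digits printed from compound 2 to compound 3 (within the scatter) and so leaves the two furan compounds alike at this position. The thiophen-2-yl group of compound 1 stands apart from furan-3-yl as well, with a 31-fold higher number from compound 1 to compound 3 (1.49 log units; beyond the scatter) and thus the same large gap already seen with furan-2-yl, so that gap does not depend on which of these two furan attachments is present. Nothing available explains why the two furans read alike or why both differ from the thiophen-2-yl compound.

As far as these compounds go, whether thiophen-3-yl would read like thiophen-2-yl or like the furans remains open. So does the place of a phenyl or pyridin-3-yl group on the same carbonyl carbon.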